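From compound 1 to compound 4: one aromatic group exchanged

This account rests on a few compounds, and the source may have more. Where it says the series, first, only, none or still open, it means among the compounds named here.

Compound 1 `CCNC(=O)c1cc(Oc2ccc(NC(=O)c3nn(-c4ccccc4OC(F)(F)F)c(=O)cc3C)cc2)ccn1`: 3990 nM
Compound 2 `CCCNC(=O)c1cc(Oc2ccc(NC(=O)c3nn(-c4ccc(C)cc4)c(=O)cc3C)cc2F)ccn1`: 14200 nM
Compound 3 `CCCNC(=O)c1cc(Oc2ccc(NC(=O)c3nn(-c4cccc(C(F)(F)F)c4)c(=O)cc3C)cc2F)ccn1`: 8000 nM

In a functional assay on HeLa cells (Homo sapiens) for antiproliferative activity, read by MTT assay, with a stated time of 72 h (on this read-out lower numbers stand for stronger inhibition and higher numbers for weaker inhibition), compound 1 gives 3990 nM. That value lies within the scatter of compound 3 at 8000 nM, whereas compound 2 at 14200 nM has a higher number, beyond the scatter.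

Compound 4 `CCNC(=O)c1cc(Oc2ccc(NC(=O)c3nn(-c4cccc(C(F)(F)F)c4)c(=O)cc3C)cc2)ccn1` differs from compound 1 by 3-(trifluoromethyl)phenyl in place of 2-(trifluoromethoxy)phenyl on an aromatic nitrogen. It has 3-(trifluoromethyl)phenyl in place of 2-(trifluoromethoxy)phenyl on an aromatic nitrogen.

Among the compounds with values here, only one measured step bears on this change: a 1.8-fold lower number from compound 2 to compound 3 (0.25 log units; within the scatter). It brings in the same group but starts from 4-methylphenyl, on a different remainder of the molecule, and it stays within the scatter. Within the data shown here, no measured step removes 2-(trifluoromethoxy)phenyl, so the evidence is indirect. With so small a step for compound 3, no shift beyond the scatter is expected in this assay, though a slightly higher number is possible.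

The estimated step is a 1.3-fold higher number from compound 1 to compound 4 (0.10 log units; within the scatter).

For compound 4 the estimated value is 5000 nM, with an expected range from 2200 nM to 11000 nM.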

Compound 4, half-maximal inhibitory concentration: 10700 nM
Compound 4: the middle estimate sits 2.1-fold (0.33 log units) below what was measured; measured number inside the range.
By their numbers in this assay, from the lowest: compounds 1, 3, 4 and 2 (each within the scatter of the next, the first and the last beyond it).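

In this assay, within the data shown here, the exchange on the aromatic nitrogen gives a 2.7-fold higher number from compound 1 to compound 4 (0.43 log units; beyond the scatter), which is beyond the scatter, whereas the only earlier step at this position stayed within it. On the core of compound 1, then, 3-(trifluoromethyl)phenyl is not a neutral replacement for 2-(trifluoromethoxy)phenyl, and the group on this nitrogen can shift the number measurably. Nothing measured here accounts for this step.

The two groups differ in both the substituent and its position on the phenyl ring, so the compounds shown do not separate these two changes. Also open, on these data alone, is how 2-(trifluoromethyl)phenyl, 3-(trifluoromethoxy)phenyl, or a phenyl ring carrying an amine would stand on the core of compound 1.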